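A few compounds are considered here, and "the series" means these few. Any claim that something is new, unique, unknown or untested is made for them only; others in the source may bear on it.

Notes on the series, read in a functional assay on brain (Rattus norvegicus, strain Wistar) for inhibition; a lower number here means a stronger inhibitor, a higher number a weaker inhibitor. Compound 1 (`CCCCc1ccc(-c2c(C)[nH]c(=O)n2C2CCCCC2)cc1`) gives 27100 nM, and compound 3 (`CCCCCCCCc1ccc(-c2c(C)[nH]c(=O)n2C2CCCCC2)cc1`) gives 10300 nM. Within the data shown here, the only measured step is a 2.6-fold lower number from compound 1 to compound 3 (0.42 log units; beyond the scatter), a modest one that extends a chain. Compound 2 (`Cc1[nH]c(=O)n(C)c1-c1ccc(Oc2ccccc2)cc1`) gives 8100 nM, and compound 3 lies within the scatter of it, so these two sit together and clear of compound 1 on the stronger side.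

The change to compound 4 (`Cc1[nH]c(=O)n(C2CCCCC2)c1-c1ccc(Oc2ccccc2)cc1`) is phenoxy in place of octyl on an aromatic carbon, para to a large group. Among the measured compounds shown here, no measured step covers this swap directly. For the measured compounds named here, compound 2, at 8100 nM, already carries phenoxy, but it differs from compound 4 elsewhere, and no measured pair isolates that difference. Going by the values given here, with the modest chain step from compound 1 as the only guide, no step beyond the scatter is expected in this assay. The expected change is a 1.3-fold lower number from compound 3 to compound 4 (0.11 log units; within the scatter). Compound 4 is estimated at 8000 nM, with an expected range of 3000 nM to 22000 nM.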

Compound 4, half-maximal inhibitory concentration: 7900 nM
Compound 4: middle estimate off by 1.0-fold (0.01 log units), on the high side, within the range that was stated.
By their numbers in this assay, from the lowest: compounds 4, 2 and 3 (each within the scatter of the next); then compound 1.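

In this assay, phenoxy in place of octyl on an aromatic carbon, para to a large group, gives a 1.3-fold lower number from compound 3 to compound 4 (0.12 log units; within the scatter), so a phenoxy ring and an octyl chain are not told apart at this position, while phenoxy in place of butyl gives a 3.4-fold lower number from compound 1 to compound 4 (0.54 log units; beyond the scatter), a modest step that matches the one seen on extending the chain. With phenoxy held, cyclohexyl in place of methyl on an aromatic nitrogen gives a 1.0-fold lower number from compound 2 to compound 4 (0.01 log units; within the scatter), so these two nitrogen groups also read alike. Nothing measured here accounts for either result.

On these data alone, whether an amine or a carboxylic acid on that aromatic carbon, or a chain longer than octyl, would separate from compounds 2, 3 and 4 stays open. Also open, as far as these compounds go, is whether a benzyl group on the aromatic nitrogen would read differently from cyclohexyl or methyl.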